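Methyl for Bromo: Plasma Half-Life of Compound 4

This account rests on a few compounds, and the source may have more. Where it says the series, first, only, none or still open, it means among the compounds named here.

The measured compounds:
Compound 1 `CC(=O)OCOC(=O)N(C)/N=N/c1ccc(Br)cc1`: 0.283 h
Compound 2 `Cc1cn([C@H]2C=C[C@@H](COC(=O)CN(C)C)O2)c(=O)[nH]c1=O`: 0.5 h
Compound 3 `O=C(OC[C@H]1O[C@@H](n2cnc3c(NC4CCCC4)ncnc32)[C@H](O)[C@@H]1O)C1CCCCC1`: 0.75 h

In an ADME assay on a cell-free system (plasma, Homo sapiens) for metabolic stability (a higher number here means that the compound lasts longer, a lower number that the compound disappears faster), compound 1 gives 0.283 h, the lowest of the three numbers. Compound 2, which gives 0.5 h, lies within the scatter of compound 1, so no order can be drawn between them. Compound 3, which gives 0.75 h, stands beyond the scatter above compound 1.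

Compound 4 `CC(=O)OCOC(=O)N(C)/N=N/c1ccc(C)cc1` differs from compound 1 in one place: methyl in place of bromo on an aromatic carbon. Among the measured compounds shown here, no measured pair shows this change, so the direction of the step is unknown. The step from compound 1 to compound 4 is expected to be small in a 1.1-fold higher number from compound 1 to compound 4 (0.03 log units; within the scatter), not beyond the scatter. For compound 4 the estimate in this assay is 0.3 h, ranging from 0.15 h to 0.6 h.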

Compound 4, half-life: 0.25 h
Compound 4: the middle estimate sits 1.2-fold (0.08 log units) above what was measured; measured number inside the range.
By their numbers in this assay, from the lowest: compounds 4, 1, 2 and 3 (each within the scatter of the next, the first and the last beyond it).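

In this assay, among the compounds shown here, methyl in place of bromo on an aromatic carbon, para to a large group, gives a 1.1-fold lower number from compound 1 to compound 4 (0.05 log units; within the scatter) and provides the first step between compounds that differ in one place. At this position, the half-life therefore does not separate methyl from bromo. Nothing available accounts for this result.

As far as these compounds go, whether an amine or a carboxylic acid at this position would also stay within the scatter of compound 1 remains open. So does whether methyl in place of bromo would read the same on another core.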